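The compounds below may be only part of what the source reports. "The series", "measured", "known", "first", "only" and "open" are said of these compounds alone.

Measured so far:
compound 1, `Cc1cc(-c2ccc3[nH]c(=O)nc(-c4ccccc4)c3c2)ccn1` — in an ADME assay on THP-1 cells (Homo sapiens) for cytotoxicity, read by MTT assay, with a stated time of 72 h (a lower number here means that less compound is needed, a higher number that more compound is needed for the effect), compound 1 gives > 50000 nM, a limit of the assay rather than a number.
compound 2, `CN1CCN(c2ccc3[nH]c(=O)nc(-c4ccccc4)c3c2)CC1` — in this assay compound 2 gives > 50000 nM, again a limit rather than a number.

Compound 2 therefore stands at the top of what this assay can report, the same place as compound 1 (the limit of > 50000 nM in this assay, at which 2 of the 2 values shown sit). Going by the values given here, the only measured step, a step that the two limits leave unreadable from compound 1 to compound 2, cannot be read, both ends being limits. Compound 3, `O=c1nc(-c2ccccc2)c2cc(N3CCNCC3)ccc2[nH]1`, differs from compound 2 by hydrogen in place of methyl on an amine nitrogen in a ring. Among the compounds with values here, no measured step touches this change, and the one step available is unreadable, so no size or direction can be taken from it. With both measured values at the limit (the limit of > 50000 nM in this assay, at which 2 of the 2 values shown sit), compound 3 is expected to sit there as well, and the step that the limit leaves unreadable from compound 2 to compound 3 is estimated to be nothing beyond scatter. For compound 3 the estimate in this assay is 60000 nM, expected to fall between 30000 nM and 150000 nM, and most likely reported once more as a limit.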

Compound 3, half-maximal effective concentration: > 25000 nM
Compound 3: a limit, no number; the forecaster's own chance of this, stated with the estimate: 85%; the middle value is on the limit's open side.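

Compound 3, like compound 1 and compound 2, is reported in this assay only as a limit, so no step among these compounds can be read. Left open is the concentration at which each would reach half-maximal effect, and whether the exchanged groups alter it.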